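This account rests on a few compounds, and the source may have more. Where it says the series, first, only, none or still open, it means among the compounds named here.

- compound 1 `COc1cccc(/C=C/C(=O)Nc2cc(OC)c(OC)c(OC)c2)c1`: 18200 nM
- compound 2 `C=C(Br)C(=O)Nc1cccc(/C=C/C(=O)Nc2ccccc2)c1`: 1100 nM
- compound 3 `C=C(Br)C(=O)Nc1cccc(/C=C/C(=O)Nc2cccc3ccccc23)c1`: 830 nM

In a functional assay on SEM cells (Homo sapiens) for inhibition, read by MTT assay, with a stated time of 72 h (on this read-out lower numbers stand for stronger inhibition and higher numbers for weaker inhibition), compound 2 gives 1100 nM, within the scatter of compound 3 at 830 nM. Compound 1 gives 18200 nM, a number clearly higher than that of compound 2. Compound 4 `C=C(Br)C(=O)Nc1cccc(/C=C/C(=O)Nc2ccc(OC(F)(F)F)cc2)c1` is built from compound 2 by one change: trifluoromethoxy in place of hydrogen on an aromatic carbon. This places trifluoromethoxy in place of hydrogen on an aromatic carbon, para to a large group. Within the data shown here, no measured pair here shows this change, so any forecast for this assay is uncertain. No shift beyond the scatter is expected, with a slight lean toward a lower number. The expected change is a 1.4-fold lower number from compound 2 to compound 4 (0.14 log units; within the scatter). For compound 4 the estimated value is 800 nM, with an expected range from 300 nM to 2200 nM.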

Compound 4, half-maximal inhibitory concentration: 19300 nM
Compound 4: the middle estimate sits 24-fold (1.38 log units) below what was measured; measured number outside the range, above it.
By their numbers in this assay, from the lowest: compounds 3 and 2 (each within the scatter of the next); then compounds 1 and 4 (each within the scatter of the next).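

In this assay, putting trifluoromethoxy in place of hydrogen on an aromatic carbon, para to a large group, gives an 18-fold higher number from compound 2 to compound 4 (1.24 log units; beyond the scatter). Among these compounds, this is the first single-change comparison here, and it shows that this position does not tolerate every group: this one addition is enough to weaken inhibition markedly. Nothing available here accounts for the size of this step. The compounds shown leave open whether a fluorine atom, a methyl group or an amine at the same place would weaken inhibition too. One group cannot show whether the loss comes with any replacement of that hydrogen or with trifluoromethoxy alone.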